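Removing a hydroxymethyl from the alkyne: does the gain carry over?

The compounds below may be only part of what the source reports. "The series", "measured", "known", "first", "only" and "open" are said of these compounds alone.

Compound 1 `OCC#Cc1nc(C#Cc2cccc(F)c2)cs1`: > 10000 nM in a functional assay on CHO cells for agonist activity at metabotropic glutamate receptor 5 (Homo sapiens), read by inositol phosphate accumulation; a higher number here means a weaker inhibitor, a lower number a stronger inhibitor
Compound 2 `C#Cc1nc(C#Cc2cccc(F)c2)cs1`: 2920 nM
Compound 3 `Cc1nc(C#Cc2cncc(C#CCO)c2)cs1`: 68.6 nM

Compound 1 reaches only the limit of > 10000 nM in this assay, at which 1 of the 3 values shown sits, in this assay, which is a limit rather than a number. Compound 2 is compound 1 with hydrogen in place of hydroxymethyl on a triple-bonded carbon, and this change gives an at least 3.4-fold lower number from compound 1 to compound 2 (0.53 log units; beyond the scatter). Compound 3 stands on a different core; the difference between the two cores is not broken down here. Compound 4 `C#Cc1cncc(C#Cc2csc(C)n2)c1` repeats the same change on compound 3, with hydrogen in place of hydroxymethyl on a triple-bonded carbon. Because the first step of an at least 3.4-fold lower number from compound 1 to compound 2 (0.53 log units; beyond the scatter) lowered the number, the step from compound 3 to compound 4 is expected to be a modest lowering as well, roughly a 2.7-fold lower number from compound 3 to compound 4 (0.44 log units; beyond the scatter). On this basis compound 4 is estimated at 25 nM in this assay, within 8 nM to 80 nM.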

Compound 4, half-maximal inhibitory concentration: 19.2 nM
The estimate for compound 4 lay 1.3-fold (0.11 log units) above the measured number; low and high end bracket the measured number.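

Putting hydrogen in place of hydroxymethyl on the triple-bonded carbon also lowers the number on the second core, with a 3.6-fold lower number from compound 3 to compound 4 (0.55 log units; beyond the scatter) in this assay. The direction of the change repeats on these two cores, but two pairs make no rule for any other core: the same change on two cores in this assay, an at least 3.4-fold lower number (0.53 log units; beyond the scatter) from compound 1 to compound 2 and a 3.6-fold lower number (0.55 log units; beyond the scatter) from compound 3 to compound 4; the limit leaves it open whether they differ. Compound 1 gives > 10000 nM, which is a limit and not a number.

The compounds shown leave open what lies between hydrogen and hydroxymethyl at this place, and what a longer chain or an amine there would do. They also leave open whether the step would keep its direction and size on a third core.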